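Expected exposure of compound 4 after swapping the pyrrolidine ring

A few compounds are considered here, and "the series" means these few. Any claim that something is new, unique, unknown or untested is made for them only; others in the source may bear on it.

Going by the values given here, compound 3 `CN1CCN(CCCS(=O)(=O)c2ccc3nc(NC(=O)NC(=O)c4cc(N5CCCC5)ccc4Cl)sc3c2)CC1` gives 640 nM in an ADME assay on the whole organism (strain Han-Wistar) for pharmacokinetics, with Rattus norvegicus as the target, read by LC-MS, at a dose of 2 mg/kg by the oral route (a lower number here means less compound in the circulation, a higher number more compound in the circulation at the dose given), which places it second highest of the three numbers measured so far. Compound 2 `CN1CCN(CCCS(=O)(=O)c2ccc3nc(NC(=O)NC(=O)c4cc(C5CC5)ccc4Cl)sc3c2)CC1` gives 1400 nM, and the step of a 2.2-fold lower number from compound 2 to compound 3 (0.34 log units; beyond the scatter) separates the two. Compound 1 `Cc1cc(C)n(-c2ccc(Cl)c(C(=O)NC(=O)Nc3nc4ccc(S(=O)(=O)CCCN5CCN(C)CC5)cc4s3)c2)n1` gives 78 nM, the lowest of the three, with the steps of an 8.2-fold higher number from compound 1 to compound 3 (0.91 log units; beyond the scatter) and an 18-fold higher number from compound 1 to compound 2 (1.25 log units; beyond the scatter) leading away from it.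

Compound 4 `Cc1ccn(-c2ccc(Cl)c(C(=O)NC(=O)Nc3nc4ccc(S(=O)(=O)CCCN5CCN(C)CC5)cc4s3)c2)n1` differs from compound 3 in a single place: 3-methyl-1H-pyrazol-1-yl in place of pyrrolidin-1-yl on an aromatic carbon. The measured step that bears most directly on this change is an 8.2-fold higher number from compound 1 to compound 3 (0.91 log units; beyond the scatter), since there a pyrazolyl group at the same place was exchanged for pyrrolidin-1-yl and the number rose by a modest amount. Compound 4 carries a 3-methyl-1H-pyrazol-1-yl group, which resembles the 3,5-dimethyl-1H-pyrazol-1-yl of compound 1 more closely than the pyrrolidin-1-yl of compound 3, so a move back toward the number of compound 1 is expected in this assay. The data do not show how the loss of one methyl on the pyrazole alone changes the number, so the expectation stays between the values of compound 1 and compound 3. Compound 4 is therefore expected to show a 4.0-fold lower number from compound 3 to compound 4 (0.60 log units; beyond the scatter). The estimated value for compound 4 is 160 nM, with a range from 55 nM to 480 nM.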

Compound 4, maximal plasma concentration: 410 nM
Compound 4: middle estimate off by 2.6-fold (0.41 log units), on the low side, and the stated range covers the measured number.
By their numbers in this assay, from the lowest: compound 1; then compounds 4 and 3 (each within the scatter of the next); then compound 2.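

In this assay, the result shows that an aromatic ring at this place, para to the chloro group, does not by itself hold the number down: with 3-methyl-1H-pyrazol-1-yl in place of pyrrolidin-1-yl there is a 1.6-fold lower number from compound 3 to compound 4 (0.19 log units; within the scatter), so these two groups cannot be told apart here, while cyclopropyl remains clearly ahead of the pyrazole, with a 3.4-fold lower number from compound 2 to compound 4 (0.53 log units; beyond the scatter). The low number of compound 1 now appears tied to a single methyl on the pyrazole rather than to the pyrazole ring as such, since removing that one methyl gives a 5.3-fold higher number from compound 1 to compound 4 (0.72 log units; beyond the scatter), a change nearly as large as replacing the whole ring with pyrrolidin-1-yl. Nothing in the data shown explains why one methyl on this ring should matter so much.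

On these data alone, what a 1H-pyrazol-1-yl group with no methyl at all would give at this place remains open, as does whether a 5-methyl-1H-pyrazol-1-yl group would behave like compound 1 or compound 4. As far as these compounds go, it is also open whether a six-membered ring such as morpholin-4-yl or piperidin-1-yl would match cyclopropyl or fall nearer pyrrolidin-1-yl.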